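Methyl to trifluoromethyl on two cores in one cell assay

The source may hold more compounds than are shown below. What is called first, only, known or untested is meant among the compounds shown, and "the series" means these compounds.

The series is followed in a functional assay on MDA-MB-231 cells (Homo sapiens) for inhibition, read by MTT assay, with a stated time of 24 h; on this read-out higher numbers stand for weaker inhibition and lower numbers for stronger inhibition. Compound 1 `Cc1ccc(-c2cc(/C=N/c3ccccc3)on2)cc1` gives 29400 nM in this assay, and compound 2 `FC(F)(F)c1ccc(-c2cc(/C=N/c3ccccc3)on2)cc1` gives 37400 nM. The step between them is a 1.3-fold higher number from compound 1 to compound 2 (0.10 log units; within the scatter), and the change it carries is trifluoromethyl in place of methyl on an aromatic carbon.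

Compound 3 `CCc1cc2ccccc2nc1-c1cc(-c2ccc(C)cc2)no1` is built on a different core. In this assay compound 3 is reported only as a limit, > 100000 nM. How the core of compound 3 differs from the core of compound 1 is not broken down here. The relevant bound is the limit of > 100000 nM in this assay, at which 1 of the 3 values shown sits.

Compound 4 `CCc1cc2ccccc2nc1-c1cc(-c2ccc(C(F)(F)F)cc2)no1` has not yet been measured in this assay. Going by the values given here, it differs from compound 3 by trifluoromethyl in place of methyl on an aromatic carbon, which is the same change, in the same place, as the one from compound 1 to compound 2.

The step from compound 1 to compound 2, a 1.3-fold higher number from compound 1 to compound 2 (0.10 log units; within the scatter), lies within the scatter, so the same change on the core of compound 3 is not expected to move the number by more than scatter either. Because compound 3 sits at the limit of > 100000 nM in this assay, at which 1 of the 3 values shown sits, the expectation for compound 4 starts from a limit rather than from a number. Compound 4 is expected to give about 150000 nM in this assay, most likely again reported only as a limit. The estimated range for compound 4 runs from 70000 nM to 400000 nM. The step from compound 3 that this estimate means is a step that the limit leaves unreadable from compound 3 to compound 4, and it is expected to stay within scatter.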

Compound 4, half-maximal inhibitory concentration: > 100000 nM
Compound 4 ended at the assay's limit; the forecaster's own chance of this, stated with the estimate: 85%; the middle value lies beyond the limit too.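

In this assay compound 4 gives > 100000 nM, a limit and not a number. No step can be read from compound 3 to compound 4, since both compounds stand at a limit: the limit of > 100000 nM in this assay, at which 2 of the 4 values shown sit.

The compounds shown leave open where compound 3 and compound 4 truly lie, and whether trifluoromethyl in place of methyl shifts the number on this core at all.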